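A few compounds are considered here, and "the series" means these few. Any claim that something is new, unique, unknown or untested is made for them only; others in the source may bear on it.

Compound 1 `CCOC(=O)c1c(NC(C)C)ncnc1Oc1ccccc1` gives 70.2% in a functional assay on the whole organism (strain Albino) for inhibition, with Mus musculus as the target, in the writhing test, at a dose of 50 mg/kg by the oral route; a lower number here means less inhibition, a higher number more inhibition at the dose given (going by the name of the read-out).
Compound 2 `CCOC(=O)c1c(Nc2ccc([N+](=O)[O-])cc2)ncnc1NC(C)C` gives 77.4% in this assay.

Of these two numbers compound 2 stands at the top, but its gap to compound 1 lies within the scatter, so the two cannot be told apart. Compound 3 `CCOC(=O)c1c(Nc2ccc(C)cc2)ncnc1NC(C)C` has not yet been measured in this assay. It differs from compound 2 by methyl in place of nitro on an aromatic carbon. Among the measured compounds shown here, with no measured step of this kind to draw on, the change is expected to stay within the scatter, with a step of a number 7.4 percentage points lower from compound 2 to compound 3 (within the scatter) from compound 2 to compound 3 that is estimated as small. Compound 3 is therefore expected to give about 70%, between 50% and 88%.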

Compound 3, a percentage reported as inhibition, in the whole organism at one dose (the size of the read-out at that dose, not a potency): 72%
The estimate for compound 3 lay 2 percentage points below the measured number; the range from low to high includes it.
By their numbers in this assay, from the lowest: compounds 1, 3 and 2 (each within the scatter of the next).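

Replacing nitro with methyl on this aromatic carbon, para to a large group, gives in this assay a number 5.4 percentage points lower from compound 2 to compound 3 (within the scatter). At this position, then, the read-out at this dose does not separate the two groups, although the nitro group carries more heavy atoms and hydrogen-bond acceptors than methyl. No evidence at hand bears on this result. From the compounds shown here alone, whether an amine or a carboxylic acid on the same carbon would keep the read-out in this range remains open, as does whether a longer chain there would.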